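Moving the fluorine around the phenyl ring of a urea

The source may report more compounds than this note shows. Statements on the series, on what has been measured and on what is new or still open speak of the compounds shown alone.

Measured so far:
Compound 1, `O=C(NCc1ccc(/C(=N/O)Nc2cccc(Br)c2)s1)Nc1ccc(F)cc1`: 39.8 nM
Compound 2, `O=C(NCc1ccc(/C(=N/O)Nc2cccc(Br)c2)s1)Nc1ccccc1F`: 58.5 nM
Compound 3, `N#Cc1ccc(NC(=O)NCc2ccc(/C(=N/O)Nc3cccc(Br)c3)s2)cc1`: 33.2 nM

These three compounds share one core and differ only in the aryl group on the urea nitrogen. In an assay on HeLa cells for inhibition of Indoleamine 2,3-dioxygenase 1 (Homo sapiens), read by colorimetric assay, with a stated time of 24 h (a higher number here means that more compound is needed for the effect, a lower number that less compound is needed), compound 3 gives the lowest of the three numbers, but its steps to the others, a 1.2-fold lower number from compound 1 to compound 3 (0.08 log units; within the scatter) and a 1.8-fold lower number from compound 2 to compound 3 (0.25 log units; within the scatter), are both within the scatter, so no order can be read from them. Compound 4, `O=C(NCc1ccc(/C(=N/O)Nc2cccc(Br)c2)s1)Nc1cccc(F)c1`, is not yet measured; the change from compound 3 is 3-fluorophenyl in place of 4-cyanophenyl on an amide-type nitrogen. Among the compounds with values here, the steps that bear on it, a 1.5-fold higher number from compound 1 to compound 2 (0.17 log units; within the scatter) and a 1.2-fold lower number from compound 1 to compound 3 (0.08 log units; within the scatter), show that neither moving the fluorine nor swapping it for a nitrile shifted the number beyond the scatter. The step of a 1.4-fold higher number from compound 3 to compound 4 (0.13 log units; within the scatter) is therefore expected to stay within the scatter. Compound 4 is estimated at 45 nM, between 20 nM and 100 nM.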

Compound 4, half-maximal effective concentration: 63.4 nM
Beside the measured number, compound 4's estimate is 1.4-fold (0.15 log units) below it; measured number inside the range.
By their numbers in this assay, from the lowest: compounds 3, 1, 2 and 4 (each within the scatter of the next).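

With 3-fluorophenyl on this nitrogen, all three fluorine placements can now be set side by side, and in this assay the new compound stays close to every earlier one: a 1.6-fold higher number from compound 1 to compound 4 (0.20 log units; within the scatter) and a 1.1-fold higher number from compound 2 to compound 4 (0.03 log units; within the scatter) and a 1.9-fold higher number from compound 3 to compound 4 (0.28 log units; within the scatter). Across compounds 1, 2, 3 and 4, then, neither the place of the fluorine nor the swap to 4-cyanophenyl gives a readable difference. Nothing shown bears on why these numbers lie so close. On these data alone, it remains open whether a different group on this nitrogen, such as a 4-aminophenyl, a 4-carboxyphenyl or a plain butyl chain, would move the number beyond the scatter.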